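Swapping the dimethoxyphenyl of a stilbene cinnamamide for pyridyl

This account rests on a few compounds, and the source may have more. Where it says the series, first, only, none or still open, it means among the compounds named here.

Measured compounds and their values in a functional assay on MDA-MB-231 cells (Homo sapiens) for inhibition, read by MTT assay, with a stated time of 48 h; a higher number here means a weaker inhibitor, a lower number a stronger inhibitor:
compound 1 `COc1cc(/C=C/c2ccc(NC(=O)/C=C/c3ccc(OC)c(OC)c3)cc2)cc(OC)c1` gives 7740 nM
compound 2 `COc1cc(/C=C/c2ccc(NC(=O)/C=C/c3cccc(F)c3)cc2)cc(OC)c1` gives 17300 nM

Within the data shown here, compound 1 stands at the lower of the two numbers in this assay; its only neighbour is compound 2, and the change a 2.2-fold higher number from compound 1 to compound 2 (0.35 log units; beyond the scatter) lies beyond the scatter. Compound 3 `COc1cc(/C=C/c2ccc(NC(=O)/C=C/c3ccccn3)cc2)cc(OC)c1` has not yet been measured. It differs from compound 1 in one place: pyridin-2-yl in place of 3,4-dimethoxyphenyl on a double-bonded chain carbon bound to a double-bonded chain carbon. Among the measured compounds shown here, the one measured step that bears on this change is the one from compound 1 to compound 2, where the 3,4-dimethoxyphenyl also gave way to a smaller ring with fewer hydrogen-bond acceptors, and the number rose modestly. Compound 3 is therefore expected to show a step of similar size and in the same upward direction, a 1.9-fold higher number from compound 1 to compound 3 (0.29 log units; within the scatter). The estimate for compound 3 in this assay is 15000 nM, with a range from 6000 nM to 40000 nM.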

Compound 3, half-maximal inhibitory concentration: 3400 nM
Compound 3: middle estimate off by 4.4-fold (0.64 log units), on the high side; the whole stated range lies above it.
By their numbers in this assay, from the lowest: compound 3; then compound 1; then compound 2.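

In this assay, replacing the 3,4-dimethoxyphenyl at this place on the chain does not have to cost activity: pyridin-2-yl gives a 2.3-fold lower number from compound 1 to compound 3 (0.36 log units; beyond the scatter) and so turns the trend seen with the earlier change around. It also gives a 5.1-fold lower number from compound 2 to compound 3 (0.71 log units; beyond the scatter) when it takes the place of 3-fluorophenyl, so the two replacement rings move the number in opposite directions from compound 1 and the loss of the dimethoxyphenyl does not by itself set the outcome. Nothing measured here explains why pyridin-2-yl gives the lower number.

Still open, from the compounds shown here alone, is whether the ring nitrogen is what matters, which an unsubstituted phenyl would help to show. Pyridin-3-yl and pyridin-4-yl would show whether the location of that nitrogen in the ring changes the number.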